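This account rests on a few compounds, and the source may have more. Where it says the series, first, only, none or still open, it means among the compounds named here.

Three compounds from this series have been examined so far. In a functional assay on IGROV-1 cells (Homo sapiens) for cytotoxicity, read by sulforhodamine B assay, with a stated time of 48 h, tested at 10 uM (on this read-out higher numbers stand for a weaker effect at the one concentration tested and lower numbers for a stronger effect), compound 1 `COc1cc(C)cc(-c2c(-c3ccnc(-c4ccc(C(C)=O)cc4)c3)cnn2CC#N)c1` gives 14%, compound 2 `Cc1cc(O)cc(-c2nn(CC#N)cc2-c2ccnc(-c3ccc(Oc4ccccc4)cc3)c2)c1` gives -74%, and compound 3 `COc1cc(C)cc(-c2nn(CC#N)cc2-c2ccnc(-c3ccc(N(C)C)cc3)c2)c1` gives -6%. Compound 3 stands second highest of the three: compound 1 lies higher, beyond the scatter, and compound 2 lies lower, also beyond the scatter. Compound 4 `Cc1cc(O)cc(-c2nn(CC#N)cc2-c2ccnc(-c3ccc(N(C)C)cc3)c2)c1` has not yet been measured in this assay. It differs from compound 3 in one place only: hydrogen in place of methyl on an oxygen on an aromatic ring. Compound 2, which also carries the hydroxy rather than the methoxy, gives -74%, though it differs from compound 3 in a second place as well. On that basis a downward step is expected, with compound 4 estimated at -50%, within -90% to 0%, a step of a number 44 percentage points lower from compound 3 to compound 4 (beyond the scatter).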

Compound 4, a percentage reported as activity, at one concentration (the size of the read-out at that concentration, not a potency): -37%
Compound 4: the middle estimate sits 13 percentage points below what was measured; the measured number falls inside the stated range.
By their numbers in this assay, from the lowest: compound 2; then compound 4; then compound 3; then compound 1.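

Hydrogen in place of methyl on an oxygen on an aromatic ring, methoxy to hydroxy, can now be read on its own in this assay, with dimethylamino unchanged: it gives a number 31 percentage points lower from compound 3 to compound 4 (beyond the scatter). With the hydroxy unchanged, dimethylamino in place of phenoxy on an aromatic carbon gives a number 37 percentage points higher from compound 2 to compound 4 (beyond the scatter), so the second place also moves the read-out by itself. Nothing available explains either step.

Going by these compounds, it remains open whether ethoxy or a longer chain on that oxygen, or an amine in place of the hydroxy, would continue this trend. On these data alone, whether the methoxy to hydroxy step has the same size alongside phenoxy also remains open.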